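A few compounds are considered here, and "the series" means these few. Any claim that something is new, unique, unknown or untested is made for them only; others in the source may bear on it.

Compound 1 `NC(=S)N/N=C1/C(=O)N(CN2CCN(c3ccnc4cc(Cl)ccc34)CC2)c2cccc(Cl)c21` and compound 2 `NC(=S)N/N=C1/C(=O)N(CN2CCN(c3ccnc4cc(C(F)(F)F)ccc34)CC2)c2cccc(Cl)c21` share one core and differ only at a single aromatic carbon on the ring system carried by the piperazine. In a functional assay on MCF7 cells (Homo sapiens) for cytotoxicity, read by sulforhodamine B assay, with a stated time of 48 h (a higher number here means a weaker inhibitor of growth, a lower number a stronger inhibitor of growth), compound 1 gives 57500 nM, and compound 2 gives 21600 nM. The change from compound 1 to compound 2 is a 2.7-fold lower number from compound 1 to compound 2 (0.43 log units; beyond the scatter). Among the measured compounds shown here, on the two numbers so far, compound 2 has the lowest number, with compound 1 as its only neighbour.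

Compound 3 `NC(=S)N/N=C1/C(=O)N(CN2CCN(c3ccnc4cc(C(F)(F)F)ccc34)CC2)c2ccccc21` keeps the trifluoromethyl of compound 2 and changes the other ring system of the core: hydrogen in place of chloro on an aromatic carbon. For the measured compounds named here, no measured step touches this chloro, so the one step that exists, the change from compound 1 to compound 2, concerns a different place and gives no direct guide. The expected size is therefore no more than modest in either direction, and most likely within the scatter. For compound 3 the estimate in this assay is 26000 nM, with a range from 8000 nM to 85000 nM, meaning an expected step of a 1.2-fold higher number from compound 2 to compound 3 (0.08 log units; within the scatter).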

Compound 3, concentration for 50% growth inhibition: 13900 nM
Beside the measured number, compound 3's estimate is 1.9-fold (0.27 log units) above it; the measured number falls inside the stated range.
By their numbers in this assay, from the lowest: compounds 3 and 2 (each within the scatter of the next); then compound 1.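

Compound 1 and compound 2 both carry the chloro on the six-membered aromatic ring of carbon only, so neither could show what that atom contributes. In this assay, hydrogen in place of chloro at this place gives a 1.6-fold lower number from compound 2 to compound 3 (0.19 log units; within the scatter), so with the trifluoromethyl held constant, the two compounds cannot be told apart and this chloro does not appear necessary for the growth inhibition seen with compound 2. No available evidence accounts for this result.

The pair tests only chloro against hydrogen, so it leaves open whether a larger or different group at this place, such as a methoxy group, an amine or a carboxylic acid, would also leave the number unchanged or would shift it beyond the scatter. Going by these compounds, it is also open whether hydrogen would be tolerated equally well with chloro rather than trifluoromethyl on the ring system carried by the piperazine, since a single pair cannot show whether the two places act independently.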